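Series notes: the step from compound 1 to compound 4

This account rests on a few compounds, and the source may have more. Where it says the series, first, only, none or still open, it means among the compounds named here.

Compound 1 `CCc1cccc(Nc2cc(NC(=O)Nc3cc(OC)cc(OC)c3)ncn2)c1` gives 23% in a functional assay on NCI-H520 cells (Homo sapiens) for inhibition, read by MTT assay, with a stated time of 48 h, tested at 10 uM; a lower number here means less inhibition, a higher number more inhibition at the concentration tested (going by the name of the read-out). Compound 2 `COc1ccc(C(F)(F)F)cc1Nc1cc(NC(=O)Nc2c(Cl)cccc2Cl)ncn1` gives 33% in this assay, and compound 3 `CC(C)(C)c1ccc(Nc2cc(NC(=O)Nc3c(Cl)cccc3Cl)ncn2)cc1` gives 22% there. On these three numbers compound 1 stands second highest, yet its gap to compound 3 and its gap to compound 2 both fall within the usual scatter, so the three are not separated. Compound 4 `COc1cc(NC(=O)Nc2cc(Nc3cc(I)ccc3OC)ncn2)cc(OC)c1` has not been measured. It differs from compound 1 in one place: 5-iodo-2-methoxyphenyl in place of 3-ethylphenyl on a nitrogen on an aromatic ring. For the measured compounds named here, no pair of measured compounds isolates this kind of change, so nothing fixes a direction. The expected step from compound 1 to compound 4 is a number 5 percentage points higher from compound 1 to compound 4 (within the scatter), essentially none beyond the scatter. Compound 4 is estimated at 28% in this assay, with a range from 12% to 45%.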

Compound 4, a percentage reported as inhibition, at one concentration (the size of the read-out at that concentration, not a potency): 55%
Compound 4: middle estimate off by 27 percentage points, on the low side; the measured number lies above the stated range.
By their numbers in this assay, from the lowest: compounds 3, 1 and 2 (each within the scatter of the next, the first and the last beyond it); then compound 4.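

In this assay, for the compounds shown here, 5-iodo-2-methoxyphenyl in place of 3-ethylphenyl on a nitrogen on an aromatic ring gives a number 32 percentage points higher from compound 1 to compound 4 (beyond the scatter) and so shows that this position can move the read-out, which the earlier compounds, with no single-place pair among them, could not show. No measurement at hand accounts for the step.

On these data alone, the iodine and the methoxy group enter together, and their separate shares remain open. Also open, as far as these compounds go, is how a carboxylic acid or a simple amine on this ring would read.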